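The source may hold more compounds than are shown below. What is called first, only, known or untested is meant among the compounds shown, and "the series" means these compounds.

Working notes on the series. Compound 1 `CC1CCN(c2nc(Cl)nc3c2ncn3Cc2ccc(/C=C/C(=O)Nc3ccccc3N)cc2)CC1` is the weaker of the two measured entries: in a functional assay on HepG2 cells (Homo sapiens) for antiproliferative activity, read by CCK-8 assay, with a stated time of 72 h, tested at 8 uM (a lower number here means a weaker effect, a higher number a stronger effect of the compound at the concentration tested), compound 1 gives 32.2%, the lowest of the two numbers. For the measured compounds named here, compound 2 `Nc1ccccc1NC(=O)/C=C/c1ccc(Cn2cnc3c(NC4CCCCC4)nc(Cl)nc32)cc1` gives 42.7% in this assay; the single measured step is a number 10.5 percentage points higher from compound 1 to compound 2 (beyond the scatter), where cyclohexylamino replaces 4-methylpiperidin-1-yl on an aromatic carbon. Compound 3 `CC1CCN(c2nc(Cl)nc3c2ncn3Cc2ccc(C(=O)Nc3ccccc3N)cc2)CC1` keeps the 4-methylpiperidin-1-yl of compound 1 and changes a different part of the molecule: (2-aminophenyl)carbamoyl in place of 2-((2-aminophenyl)carbamoyl)ethenyl on an aromatic carbon. Going by the values given here, no measured step touches this position, so the one step recorded bears only on the other side of the shared core and gives no direct guide. With that, the expectation for compound 3 rests on the change alone and is held close to compound 1, with a wide range in both directions; compound 3 is expected to give 26% (range 8% to 45%) in this assay, a step of a number 6.2 percentage points lower from compound 1 to compound 3 (within the scatter) that is estimated to stay near the scatter.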

Compound 3, a percentage reported as inhibition, at one concentration (the size of the read-out at that concentration, not a potency): 65.3%
Estimate against measurement, compound 3: 39.3 percentage points below; the whole stated range lies below it.
By their numbers in this assay, from the lowest: compound 1; then compound 2; then compound 3.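

In this assay, the position on the aromatic carbon para to a large group proves sensitive: (2-aminophenyl)carbamoyl in place of 2-((2-aminophenyl)carbamoyl)ethenyl gives a number 33.1 percentage points higher from compound 1 to compound 3 (beyond the scatter), a large step at a site the earlier step did not touch. With the 4-methylpiperidin-1-yl group held constant, the ethenyl link is thus shown to be dispensable for this read-out at the concentration tested, and its removal goes with a higher number, although this is one pair and a single-concentration read-out, not a potency. No measurement at hand accounts for the step.

As far as these compounds go, whether the step comes from the double bond or from the length of the link stays open, and a saturated 2-((2-aminophenyl)carbamoyl)ethyl group at this position would separate the two. Also open, from the compounds shown here alone, is whether the same change holds with cyclohexylamino in place of 4-methylpiperidin-1-yl.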